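A Pyrrolidine for a Pyridine on an Inactive Scaffold

The source may hold more compounds than are shown below. What is called first, only, known or untested is meant among the compounds shown, and "the series" means these compounds.

compound 1, `COc1ccc(-c2noc(-c3cccnc3)n2)cc1OC1CCCC1`: > 1000000 nM
compound 2, `COc1ccc(-c2noc(Cc3c[nH]c4ccccc34)n2)cc1OC1CCCC1`: > 1000000 nM

In a functional assay on LNCaP cells (Homo sapiens) for antiproliferative activity, read by MTT assay, with a stated time of 24 h (a higher number here means a weaker inhibitor, a lower number a stronger inhibitor), compound 1 reports only a limit, > 1000000 nM, which is a boundary of the test and not a measured concentration. Compound 2 likewise gives only a limit in this assay, > 1000000 nM. Within the data shown here, both results rest at the same boundary, (the limit of > 1000000 nM in this assay, at which 2 of the 2 values shown sit), so the two compounds cannot be told apart and no step between measured compounds can be drawn. Compound 1 therefore stands at the limit, with no measured potency of its own to rank against.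

Compound 3, `COc1ccc(-c2noc(C3CCCN3)n2)cc1OC1CCCC1`, has not yet been measured. It differs from compound 1 in one place: pyrrolidin-2-yl in place of pyridin-3-yl on an aromatic carbon. With both measured compounds sitting at the limit, the expected step in this assay is none beyond the scatter, and the most likely outcome is once more a limit rather than a number. The estimate for compound 3 is 2000000 nM, within a range of 300000 nM to 10000000 nM. The step this estimate means, a step that the limit leaves unreadable from compound 1 to compound 3, is expected to fall within the scatter.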

Compound 3, half-maximal inhibitory concentration: 43 nM
Estimate against measurement, compound 3: 47000-fold (4.67 log units) above; the measured number lies below the stated range.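

Compound 1 and compound 2 gave only limits, so they could not show that the group at this place, on the aromatic carbon next to the ring nitrogen and next to the ring oxygen, has any bearing on the read-out. In this assay the exchange of pyridin-3-yl for pyrrolidin-2-yl gives an at least 23000-fold lower number from compound 1 to compound 3 (4.36 log units; beyond the scatter) and so shows that this one place, with the rest of the core of compound 1 unchanged, can separate a compound at the limit from a compound with a measured potency. The size of this step is only a minimum, as its starting point is a limit of the assay and not a number: the limit of > 1000000 nM in this assay, at which 2 of the 3 values shown sit.

The change alters several things at once: the ring goes from six-membered aromatic to five-membered non-aromatic, and pyrrolidin-2-yl has 1 hydrogen-bond donor where pyridin-3-yl has 0, and the compounds shown do not separate these. They also leave open how piperidin-2-yl, an N-methylpyrrolidin-2-yl group or an open-chain amine such as aminomethyl would read at this place.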